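The source may report more compounds than this note shows. Statements on the series, on what has been measured and on what is new or still open speak of the compounds shown alone.

Going by the values given here, in a functional assay on MV4-11 cells (Homo sapiens) for inhibition, read by resazurin assay, with a stated time of 72 h (on this read-out lower numbers stand for stronger inhibition of growth and higher numbers for weaker inhibition of growth), compound 1 `O=C1NCCC12CCN(c1c(Cl)cncc1-c1cc[nH]c1)CC2` gives 1050 nM, and compound 2 `O=Cc1cc(-c2cncc(Cl)c2N2CCC3(CCNC3=O)CC2)co1` gives 5150 nM, the higher of the two numbers so far. Compound 3 `O=Cc1cc(-c2cncc(Cl)c2N2CCC3(CCNC3=O)CC2)cs1` carries 5-formylthiophen-3-yl in place of 5-formylfuran-3-yl on an aromatic carbon, ortho to a large group: 5-formylthiophen-3-yl in place of 5-formylfuran-3-yl on an aromatic carbon. Among the compounds with values here, the only measured step, a 4.9-fold higher number from compound 1 to compound 2 (0.69 log units; beyond the scatter), is modest and beyond the scatter, but it exchanges 1H-pyrrol-3-yl for 5-formylfuran-3-yl, so it bears only loosely on this change. No step beyond the scatter is expected in this assay. The estimated step is a 1.3-fold lower number from compound 2 to compound 3 (0.11 log units; within the scatter). Compound 3 is expected at 4000 nM, with an estimated range of 1500 nM to 10000 nM.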

Compound 3, concentration for 50% growth inhibition: 730 nM
Compound 3: the middle estimate sits 5.5-fold (0.74 log units) above what was measured, and the stated range ends above it.
By their numbers in this assay, from the lowest: compounds 3 and 1 (each within the scatter of the next); then compound 2.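

At this position, on an aromatic carbon ortho to a large group, the five-membered ring itself counts in this assay: 5-formylthiophen-3-yl in place of 5-formylfuran-3-yl gives a 7.1-fold lower number from compound 2 to compound 3 (0.85 log units; beyond the scatter) and so restores the level of compound 1. Against 1H-pyrrol-3-yl, the same group gives a 1.4-fold lower number from compound 1 to compound 3 (0.16 log units; within the scatter) and stays within the scatter, so carrying a formyl group does not by itself go with the higher number; only compound 2 stands apart. No supporting data bear on this gap between the furan and thiophene rings.

On these data alone, whether the formyl group contributes on the thiophene ring remains open. Also open, as far as these compounds go, is how a carboxylic acid or an aminomethyl group would read in its place.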